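The compounds below may be only part of what the source reports. "The series", "measured", "known", "first", "only" and "open" are said of these compounds alone.

Compound 1 (`CCCCCCCCCCNc1ccn([C@H]2C[C@H](O)[C@@H](CO)O2)c(=O)n1`) and compound 2 (`CCCCCCCCCCCCCCNc1ccn([C@H]2C[C@H](O)[C@@H](CO)O2)c(=O)n1`) share a core and differ only in the length of the saturated chain on a nitrogen on an aromatic ring. Within the data shown here, in an ADME assay on A549 cells (Homo sapiens) for cytotoxicity, read by MTT assay (a higher number here means that more compound is tolerated, a lower number that less compound is tolerated), compound 1 gives 200000 nM and compound 2 gives 90000 nM, the lower of the only two numbers so far. Among the measured compounds shown here, the single measured step, a 2.2-fold lower number from compound 1 to compound 2 (0.35 log units; beyond the scatter), came with the longer chain.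

Compound 3 (`O=c1nc(NCCCCc2ccccc2)ccn1[C@H]1C[C@H](O)[C@@H](CO)O1`) shortens that chain and ends it in a ring: phenyl in place of decyl on a saturated chain carbon, four bonds along the chain from a nitrogen on an aromatic ring. For the measured compounds named here, no measured compound carries such a ring, so compound 2 and compound 1 offer only a rough guide. If the trend simply reverses with a shorter chain, a moderate rise in this assay is expected. This means an expected 2.8-fold higher number from compound 2 to compound 3 (0.44 log units; beyond the scatter). For compound 3 the estimated value is 250000 nM, with an expected range of 100000 nM to 600000 nM.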

Compound 3, half-maximal cytotoxic concentration: 90000 nM
Compound 3: the middle estimate sits 2.8-fold (0.44 log units) above what was measured; the measured number lies below the stated range.
By their numbers in this assay, from the lowest: compounds 2 and 3 (each within the scatter of the next); then compound 1.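

In this assay, the swap of decyl for phenyl gives no change at the digits printed from compound 2 to compound 3 (within the scatter), so at this position a shorter chain ending in a ring cannot be told apart from the longest plain chain. The swap of hexyl for phenyl gives a 2.2-fold lower number from compound 1 to compound 3 (0.35 log units; beyond the scatter), which shows that lengthening the plain chain is not the only change among these compounds that goes with a lower number: a chain ending in phenyl goes with one too. Nothing available here explains why these two different chains give such similar numbers.

Going by these compounds, it remains open how much of the result belongs to the phenyl ring and how much to the chain that carries it. A plain butyl chain, or cyclohexyl in place of phenyl, would help separate the two, and an amine or a carboxylic acid at the chain end remains a further open case.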